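Methoxy in place of hydrogen on the core of compound 2

A few compounds are considered here, and "the series" means these few. Any claim that something is new, unique, unknown or untested is made for them only; others in the source may bear on it.

Of the compounds shown here, three sharing one core have been tested in a toxicity assay on the whole organism (strain Icem-CET (SPF Caw)) for cytotoxicity, with Mus musculus as the target; a lower number here means that less compound is needed, a higher number that more compound is needed for the effect. Compound 2 `C=CCNC(=O)/C(C)=C(/C)c1ccccc1` gives 550 mg/kg, the highest of the three numbers, although neither of the other two is separated from it by more than the usual scatter. Compound 1 `C=CCNC(=O)/C(C)=C(/C)c1ccc(Br)cc1` carries a bromo group on the aromatic ring and gives 400 mg/kg; compound 3 `C/C(C(=O)NC1CC1)=C(\C)c1ccccc1` carries a cyclopropyl group on the amide nitrogen instead of the allyl group and gives 400 mg/kg.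

Compound 4 `C=CCNC(=O)/C(C)=C(/C)c1ccc(OC)cc1` has not yet been measured. It differs from compound 2 by methoxy in place of hydrogen on an aromatic carbon. The step that bears most directly on this change is the one at the same aromatic position, a 1.4-fold higher number from compound 1 to compound 2 (0.14 log units; within the scatter), since bromo and hydrogen at that place gave numbers within the scatter of one another. The other step, a 1.4-fold lower number from compound 2 to compound 3 (0.14 log units; within the scatter), lies elsewhere in the molecule and also stayed within the scatter. With only these two small steps to go on, no shift beyond the scatter is expected in this assay from the methoxy group, and the estimate for the step is a 1.1-fold lower number from compound 2 to compound 4 (0.04 log units; within the scatter). Compound 4 is therefore expected to give about 500 mg/kg, with a plausible range from 300 mg/kg to 850 mg/kg.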

Compound 4, dose for half-maximal effect: 280 mg/kg
Compound 4: middle estimate off by 1.8-fold (0.25 log units), on the high side, and the stated range ends above it.
By their numbers in this assay, from the lowest: compounds 4, 1, 3 and 2 (each within the scatter of the next).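

In this assay methoxy in place of hydrogen on the aromatic carbon para to a large group gives a 2.0-fold lower number from compound 2 to compound 4 (0.29 log units; within the scatter), so a group that enters with an oxygen atom and one hydrogen-bond acceptor still leaves the step within the scatter at this place. Methoxy in place of bromo on the same carbon gives a 1.4-fold lower number from compound 1 to compound 4 (0.15 log units; within the scatter), which means that hydrogen, bromo and methoxy at this place now all stand within the scatter of one another, where the earlier compounds could show this only for hydrogen and bromo. Nothing given here offers an explanation for these numbers.

The compounds shown leave open whether an amine or a carboxylic acid at this place, or a longer chain such as ethoxy, would give a step beyond the scatter in this assay. They also leave open what methoxy on the aromatic carbon gives when cyclopropyl stands on the amide-type nitrogen in place of allyl, as the step at that nitrogen is shown only with hydrogen on the ring.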